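The compounds below may be only part of what the source reports. "The series", "measured", "known", "first", "only" and "open" are said of these compounds alone.

Compound 1 `CCCc1ccc(COC(=O)N[C@H]2CNC2=O)cc1` gives 52 nM in an assay on HEK293 cells for inhibition of N-acylethanolamine-hydrolyzing acid amidase (Homo sapiens), read by fluorescence, with stated times of 10 min and 50 min; a lower number here means a stronger inhibitor, a higher number a weaker inhibitor.
Compound 2 `CCCCc1ccc(COC(=O)N[C@H]2CNC2=O)cc1` gives 23 nM in this assay.

Compound 2 stands lowest of the two numbers in this assay; the step of a 2.3-fold lower number from compound 1 to compound 2 (0.35 log units; beyond the scatter) lies beyond the scatter. Compound 3 `CC(C)(C)c1ccc(COC(=O)N[C@H]2CNC2=O)cc1` differs from compound 2 by tert-butyl in place of butyl on an aromatic carbon. For the measured compounds named here, the one measured step lengthened the chain, whereas here the same atoms are rearranged, so it bears on the change only loosely and no step beyond the scatter is expected. The step from compound 2 to compound 3 in this assay is estimated as a 1.5-fold higher number from compound 2 to compound 3 (0.18 log units; within the scatter). Compound 3 is expected at 35 nM, within 12 nM to 100 nM.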

Compound 3, half-maximal inhibitory concentration: 310 nM
Beside the measured number, compound 3's estimate is 8.9-fold (0.95 log units) below it; measured number above the stated range.
By their numbers in this assay, from the lowest: compound 2; then compound 1; then compound 3.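

On an aromatic carbon para to a large group, rearranging the same atoms has a far larger effect in this assay than lengthening the chain did: the change to tert-butyl gives a 13-fold higher number from compound 2 to compound 3 (1.13 log units; beyond the scatter) and also a 6.0-fold higher number from compound 1 to compound 3 (0.78 log units; beyond the scatter) so the branched group falls behind even the shorter propyl. Across these compounds, the shape of the group at this position therefore weighs more than the chain length. No evidence at hand accounts for the loss.

As far as these compounds go, it remains open whether a longer chain such as hexyl lowers the number further. From the compounds shown here alone, it is also open whether isopropyl or cyclopropyl carries the same loss as tert-butyl.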